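Trifluoromethoxy for trifluoromethyl on a dichloroacetanilide

A few compounds are considered here, and "the series" means these few. Any claim that something is new, unique, unknown or untested is made for them only; others in the source may bear on it.

This small set is built on a dichloroacetamide attached to a benzene ring. Compound 1, `O=C(Nc1ccccc1)C(Cl)Cl`, carries the plain ring; in a functional assay on Bel-7402 cells (Homo sapiens) for antiproliferative activity, read by MTT assay, with a stated time of 72 h (on this read-out lower numbers stand for stronger inhibition and higher numbers for weaker inhibition), compound 1 is recorded as "not determined" (no result reported). Compound 2, `O=C(Nc1cccc(C(F)(F)F)c1)C(Cl)Cl`, bears a trifluoromethyl group on the ring, and in this assay compound 2 gives 5970 nM. Among the measured compounds shown here, that is the only number in hand, so compound 2 stands alone as the reference point, with nothing measured to compare against it.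

Compound 3, `O=C(Nc1cccc(OC(F)(F)F)c1)C(Cl)Cl`, is the next variation: trifluoromethoxy in place of trifluoromethyl on an aromatic carbon. The two groups are close in size and both lack a hydrogen-bond donor; the trifluoromethoxy group brings one extra oxygen and one hydrogen-bond acceptor. For the measured compounds named here, with no measured pair of this kind to lean on, the change is expected to shift activity only modestly, in either direction, and most likely not beyond the usual scatter of repeated measurements. The estimated step in this assay is therefore a 1.1-fold lower number from compound 2 to compound 3 (0.04 log units; within the scatter), a change expected to be small. Compound 3 is accordingly estimated at 5500 nM in this assay, within an expected range from 2000 nM to 15000 nM.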

Compound 3, half-maximal inhibitory concentration: 10300 nM
Compound 3: middle estimate off by 1.9-fold (0.27 log units), on the low side, and the stated range covers the measured number.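

In this assay the change from trifluoromethyl to trifluoromethoxy on this aromatic carbon gives a 1.7-fold higher number from compound 2 to compound 3 (0.24 log units; within the scatter) and so leaves the two compounds indistinguishable on this read-out. Among the compounds shown here, this is the only measured pair in the set, and it shows that, at this place on the ring, the extra oxygen and its hydrogen-bond acceptor bring no difference that stands clear of the variation expected between repeated measurements. The data offer no measured property of either group that could explain why the two compounds read alike.

With the plain ring of compound 1 recorded as "not determined" (no result reported), what either fluorinated group contributes compared with no substituent at all cannot be read from these compounds. As far as these compounds go, it also remains open whether a quite different group at this place, such as an amine, a carboxylic acid or a longer alkyl chain, would move the number in this assay beyond the scatter, and whether the same swap would behave alike on another carbon of the ring.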